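The source may hold more compounds than are shown below. What is called first, only, known or untested is meant among the compounds shown, and "the series" means these compounds.

Among the measured compounds shown here, compound 2 `COc1ccc(C2CC(c3ccco3)=NN2C(C)=O)cc1` stands lowest of the two numbers so far: in a functional assay on IMR-32 cells (Homo sapiens) for cytotoxicity, read by sulforhodamine B assay, with a stated time of 48 h (a lower number here means a stronger inhibitor, a higher number a weaker inhibitor), compound 2 gives 14500 nM, while compound 1 `CC(=O)N1N=C(c2ccco2)CC1c1ccc([N+](=O)[O-])cc1` gives 35800 nM. For the measured compounds named here, the single measured step, a 2.5-fold lower number from compound 1 to compound 2 (0.39 log units; beyond the scatter), was modest. Compound 3 `CC(=O)N1N=C(c2ccco2)CC1c1ccc(N(C)C)cc1` continues from compound 2 by dimethylamino in place of methoxy on an aromatic carbon. That earlier step bears on it only loosely, since here one uncharged group replaces another rather than nitro, so a small step in the same direction, or none beyond the scatter, is expected, namely a 1.5-fold lower number from compound 2 to compound 3 (0.16 log units; within the scatter). Compound 3 is therefore estimated at 10000 nM, with a range from 4000 nM to 30000 nM.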

Compound 3, half-maximal inhibitory concentration: 16100 nM
Compound 3: the middle estimate sits 1.6-fold (0.21 log units) below what was measured, and the stated range covers the measured number.
By their numbers in this assay, from the lowest: compounds 2 and 3 (each within the scatter of the next); then compound 1.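

In this assay dimethylamino and methoxy on this aromatic carbon cannot be told apart (a 1.1-fold higher number from compound 2 to compound 3 (0.05 log units; within the scatter)), which the first two compounds alone could not show. Dimethylamino also stands clear of nitro (a 2.2-fold lower number from compound 1 to compound 3 (0.35 log units; beyond the scatter)), a modest step of about the same size as the one from nitro to methoxy. No measurement here explains these results. Still open, from the compounds shown here alone, is how a plain hydrogen, a chlorine or a hydroxyl at this place would compare. Going by these compounds, all three compounds also share one core, so the effect of changes elsewhere in it remains unknown.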